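A few compounds are considered here, and "the series" means these few. Any claim that something is new, unique, unknown or untested is made for them only; others in the source may bear on it.

Values in a functional assay (microsomes, liver) with Rattus norvegicus as the target; a lower number here means a stronger inhibitor, a higher number a weaker inhibitor:
- compound 1 `Cc1c(C)c2c(c(N)c1N)CC(C)(C)O2`: 300 nM
- compound 2 `CC(C)=Cc1c(C)c(N)c(C)c2c1OC(C)(C)C2`: 300 nM
- compound 3 `Cc1c(C)c2c(c(C)c1N)CC(C)(CSc1ccc(F)cc1)O2`: 220 nM

These three values sit close together. Compound 3, at 220 nM, lies within the usual scatter of both compound 1 and compound 2, so the numbers do not separate the three compounds.

The next compound is compound 4 `CCCSCC1(C)Cc2c(C)c(N)c(C)c(C)c2O1`, which keeps the sulfur side chain of compound 3 but has propyl in place of 4-fluorophenyl on that sulfur: propyl in place of 4-fluorophenyl on a sulfur. For the measured compounds named here, no pair of measured compounds differs in one place only, so no measured step shows what a swap at this sulfur does. The expectation therefore rests on a looser observation. Compound 3 differs from compound 2 in more than one place, yet the two lie within the scatter of each other, with compound 2 at 300 nM. On that basis, no step beyond the scatter is expected in this assay, and any drift may run slightly towards a higher number. The expected change is a 1.2-fold higher number from compound 3 to compound 4 (0.07 log units; within the scatter), though this is only a rough estimate from very few data. For compound 4 the estimated value is 260 nM, with an expected range from 100 nM to 650 nM.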

Compound 4, half-maximal inhibitory concentration: 280 nM
The estimate for compound 4 lay 1.1-fold (0.03 log units) below the measured number; low and high end bracket the measured number.
By their numbers in this assay, from the lowest: compounds 3, 4, 1 and 2 (each within the scatter of the next).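

In this assay, exchanging the 4-fluorophenyl on the sulfur for propyl gives a 1.3-fold higher number from compound 3 to compound 4 (0.10 log units; within the scatter), and this is the only step among these compounds in which a single place changes. It shows that the group on this sulfur, whose other neighbour is a saturated chain carbon, can go from 7 heavy atoms with an aromatic ring to 3 heavy atoms with no ring and no separation appears in the numbers, so at this position and for this one exchange, the aromatic ring and the fluorine are not needed to keep the value within the scatter. No measurement is available that would explain this result or link it to any property of either group.

As far as these compounds go, a single step within the scatter cannot show how far this freedom extends, so it remains open whether a longer chain, a chain ending in an amine or a carboxylic acid, or an unsubstituted phenyl on the sulfur would also stay within the scatter. From the compounds shown here alone, the role of the sulfur itself also remains open, since both compounds in this step carry it, and an oxygen in its place could give a different picture.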